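The compounds below may be only part of what the source reports. "The series", "measured", "known", "first", "only" and "open" are said of these compounds alone.

Going by the values given here, compound 2 `CC(C)C[C@H](N)c1cc(C(F)(F)F)ccc1N1CCN(C(=O)CC(C)C(=O)c2ccc(Cl)cc2)CC1` stands at the lower of the two numbers so far in an assay on HEK293 cells for displacement of a labelled ligand from Melanocortin receptor 4 (Homo sapiens); a higher number here means a weaker inhibitor, a lower number a stronger inhibitor: compound 2 gives 1100 nM, while compound 1 `COc1ccc(OCC(=O)N2CCN(c3ccc(C(F)(F)F)cc3[C@@H](N)CC(C)C)CC2)cc1` gives 3800 nM in this assay. Among the compounds with values here, the single measured step between them, a 3.5-fold lower number from compound 1 to compound 2 (0.54 log units; beyond the scatter), is the only one available. Compound 3 `Cc1ccc(OCC(=O)N2CCN(c3ccc(C(F)(F)F)cc3[C@@H](N)CC(C)C)CC2)cc1` differs from compound 2 by the change (4-methylphenoxy in place of 1-((4-chlorophenyl)carbonyl)ethyl on a saturated chain carbon bound to a carbonyl carbon). The group that enters in compound 3 is a close relative of the 4-methoxyphenoxy group of compound 1, so the step from compound 2 to compound 3 largely retraces the measured step in the opposite direction; that step lay beyond the scatter, and a rise of similar size is therefore expected in this assay, with some room for the methyl in place of methoxy to shift the number either way. On this basis compound 3 is expected to give about 3000 nM in this assay. The expected step is a 2.7-fold higher number from compound 2 to compound 3 (0.44 log units; beyond the scatter). For compound 3 the estimated range runs from 1200 nM to 8000 nM.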

Compound 3, inhibition constant: 4400 nM
Compound 3: middle estimate off by 1.5-fold (0.17 log units), on the low side; low and high end bracket the measured number.
By their numbers in this assay, from the lowest: compound 2; then compounds 1 and 3 (each within the scatter of the next).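

In this assay, methyl and methoxy on the aromatic carbon of the phenoxy group cannot be told apart: a 1.2-fold higher number from compound 1 to compound 3 (0.06 log units; within the scatter). The gap to the 1-((4-chlorophenyl)carbonyl)ethyl group, by contrast, holds up with a second phenoxy group, a 4.0-fold higher number from compound 2 to compound 3 (0.60 log units; beyond the scatter), so it no longer rests on the 4-methoxyphenoxy group of compound 1 alone. No measurement shown here offers an explanation for either the gap or the absence of a readable change between the two phenoxy groups.

The change from compound 2 to compound 3 replaces the carbonyl, the chlorine, the branching methyl and the ether oxygen in one step, so the compounds shown do not tell which of these features accounts for the lower number of compound 2. From the compounds shown here alone, it also remains open whether a 4-chlorophenoxy group would stay level with compounds 1 and 3 or come closer to compound 2, and whether an amine or a carboxylic acid on the same aromatic carbon would move the number at all.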